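Dropping the trifluoromethyl from a weak anilide

The source may hold more compounds than are shown below. What is called first, only, known or untested is meant among the compounds shown, and "the series" means these compounds.

Measured so far:
compound 1 `O=C(Nc1ccc(C(F)(F)F)cc1)C1CCc2ccccc2N1` with 24200 nM
compound 2 `O=C(Nc1cc(C(F)(F)F)cc(C(F)(F)F)c1)C1CCc2ccccc2N1C(=O)c1ccccc1` with 2430 nM

Of the compounds shown here, two have been tested in a functional assay on MDA-MB-231 cells (Homo sapiens) for cytotoxicity, read by sulforhodamine B assay, with a stated time of 72 h; a lower number here means a stronger inhibitor of growth, a higher number a weaker inhibitor of growth. Compound 1 gives 24200 nM, the higher of the two numbers and so the weaker inhibitor of growth. Compound 2, which carries two trifluoromethyl groups and a benzoyl on the core, gives 2430 nM, a lower number by a margin beyond the usual scatter; since the two structures differ in more than one place, the values show only that, and no single change can be credited.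

The next compound, compound 3 `O=C(Nc1ccccc1)C1CCc2ccccc2N1`, differs from compound 1 in one place: hydrogen in place of trifluoromethyl on an aromatic carbon. Going by the values given here, no measured pair shows the effect of this change on its own, so the direction is open. Starting from a weak inhibitor of growth, a small worsening is expected, a 1.7-fold higher number from compound 1 to compound 3 (0.22 log units; within the scatter), most likely within the scatter. Compound 3 is expected to give 40000 nM, in the range from 15000 nM to 120000 nM.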

Compound 3, concentration for 50% growth inhibition: 108000 nM
Compound 3: middle estimate off by 2.7-fold (0.43 log units), on the low side, within the range that was stated.
By their numbers in this assay, from the lowest: compound 2; then compound 1; then compound 3.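

In this assay, putting hydrogen in place of trifluoromethyl on an aromatic carbon, para to a large group, gives a 4.5-fold higher number from compound 1 to compound 3 (0.65 log units; beyond the scatter). Going by these compounds alone, this is the first single change whose effect can be read, and it shows that, on this core, the compound with trifluoromethyl at this position is the stronger inhibitor of growth of the pair, though compound 1 itself remains weak. No measurement available here accounts for this step.

On these data alone, it remains open whether trifluoromethyl is special here or whether other groups at this position, such as a chlorine atom, a methoxy group or a nitrile, would serve as well. As far as these compounds go, it is also open whether the same change would have a similar effect on a core carrying a benzoyl group, as in compound 2.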